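This account rests on a few compounds, and the source may have more. Where it says the series, first, only, none or still open, it means among the compounds named here.

Measured in an ADME assay on BaF3 cells (Mus musculus) for cytotoxicity (on this read-out higher numbers stand for an effect only at larger amounts of compound and lower numbers for an effect already at smaller amounts), so far:
compound 1 `FC(F)(F)Oc1ccc(Nc2ncnc3c2cnn3C2CCCCC2)cc1` gives 9300 nM
compound 2 `CCCn1ncc2c(Nc3ccc(OC(F)(F)F)cc3)ncnc21` gives 6600 nM
compound 3 `OCCn1ncc2c(Nc3ccc(OC(F)(F)F)cc3)ncnc21` gives > 10000 nM

Compound 3 stands apart from the other two in that its value is a limit of this assay and not a number. Of the three values shown, one sits at that limit, as the evidence notes (the limit of > 10000 nM in this assay, at which 1 of the 3 values shown sits). The steps among the measured compounds are all small: a 1.4-fold lower number from compound 1 to compound 2 (0.15 log units; within the scatter), an at least 1.0-fold higher number from compound 1 to compound 3 (0.03 log units; that floor lies within the scatter), and an at least 1.5-fold higher number from compound 2 to compound 3 (0.18 log units; that floor lies within the scatter). Each of these changes the group on the aromatic nitrogen and each stays within the scatter.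

Compound 4 `FC(F)(F)Oc1ccc(Nc2ncnc3c2cnn3CC2CCOC2)cc1` is the next member. It differs from compound 3 by oxolan-3-yl in place of hydroxymethyl on a saturated chain carbon bound to an aromatic nitrogen. Among the compounds with values here, the step that bears most directly on it is the one from compound 2 to compound 3, since it also alters the chain carried by the aromatic nitrogen, and that step did not exceed the scatter; the two steps from compound 1 point the same way. The analyst therefore expects no movement beyond the scatter from compound 3 to compound 4 in this assay, a number no higher from compound 3 to compound 4 (the limit leaves the size open). For compound 4 the estimated value is 10000 nM, expected to fall between 4000 nM and 25000 nM, with a real chance that this assay again reports only a limit.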

Compound 4, half-maximal effective concentration: > 10000 nM
Compound 4: no number, only a limit (the forecaster's own chance of this, stated with the estimate: 50%); the middle value sits exactly at the limit.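

In this assay compound 4 gives > 10000 nM, which is a limit of the assay and not a number. Among the earlier compounds, only compound 3, with its 2-hydroxyethyl group, had reached this limit, whereas compound 4 reaches it with (oxolan-3-yl)methyl, which has a five-membered non-aromatic ring and 0 hydrogen-bond donors, so the hydroxy group is not required for a result at the limit, and the readable steps show an at least 1.5-fold higher number from compound 2 to compound 4 (0.18 log units; that floor lies within the scatter) and an at least 1.0-fold higher number from compound 1 to compound 4 (0.03 log units; that floor lies within the scatter). The step from compound 3 to compound 4 cannot be read, as both values are limits, and such values now make up a sizeable share of the series: the limit of > 10000 nM in this assay, at which 2 of the 4 values shown sit.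

The compounds shown leave open how far past the limit compound 3 and compound 4 lie, and so whether oxolan-3-yl and hydroxymethyl differ at this place at all. They also leave open whether an amine or a carboxylic acid on the chain at the aromatic nitrogen would give a number in this assay rather than a limit.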